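Carbamoyl for Sulfonyl on Two Sugar-Linked Enone Cores

The compounds below may be only part of what the source reports. "The series", "measured", "known", "first", "only" and "open" are said of these compounds alone.

Compound 1, `CC(=O)OC[C@H]1O[C@@H](CC(=O)/C=C/c2cccc(NC(=O)Nc3ccccc3)c2)[C@H](OC(C)=O)[C@@H](OC(C)=O)[C@@H]1OC(C)=O`, gives 180000 nM
Compound 2, `CC(=O)OC[C@H]1O[C@@H](CC(=O)/C=C/c2cccc(NS(=O)(=O)c3ccc(C)cc3)c2)[C@H](OC(C)=O)[C@@H](OC(C)=O)[C@@H]1OC(C)=O`, gives 584000 nM
Compound 3, `Cc1ccc(S(=O)(=O)Nc2cccc(/C=C/C(=O)C[C@@H]3OC[C@@H](O)[C@H](O)[C@H]3O)c2)cc1`, gives 94700 nM

These values come from an ADME assay on Vero cells (Chlorocebus sabaeus) for cytotoxicity, read by resazurin assay, with a stated time of 2 days; a lower number here means that less compound is tolerated, a higher number that more compound is tolerated. Compound 1 and compound 2 share a core; compound 3 carries another core, and the difference between the two cores is not broken down here. The change phenylcarbamoyl in place of (4-methylphenyl)sulfonyl on a nitrogen on an aromatic ring is measured in this assay as a 3.2-fold lower number from compound 2 to compound 1 (0.51 log units; beyond the scatter). Compound 4, `O=C(/C=C/c1cccc(NC(=O)Nc2ccccc2)c1)C[C@@H]1OC[C@@H](O)[C@H](O)[C@H]1O`, is not yet measured; it arises from compound 3 by phenylcarbamoyl in place of (4-methylphenyl)sulfonyl on a nitrogen on an aromatic ring, the same change at the same place with the same neighbours around it, so the same kind of step is expected. Resting on that single earlier step alone, compound 4 is expected to give 35000 nM, a move of a 2.7-fold lower number from compound 3 to compound 4 (0.43 log units; beyond the scatter), with the likely span 12000 nM to 110000 nM.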

Compound 4, half-maximal cytotoxic concentration: 309000 nM
Beside the measured number, compound 4's estimate is 8.8-fold (0.95 log units) below it; the measured number lies above the stated range.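

In this assay, the swap of (4-methylphenyl)sulfonyl for phenylcarbamoyl on the nitrogen now gives a 3.3-fold higher number from compound 3 to compound 4 (0.51 log units; beyond the scatter). Set against the earlier step, the same change moves the number in opposite directions on the two cores: the same change on two cores in this assay, a 3.2-fold lower number (0.51 log units; beyond the scatter) from compound 2 to compound 1 and a 3.3-fold higher number (0.51 log units; beyond the scatter) from compound 3 to compound 4, 11-fold (1.02 log units) apart, beyond the scatter of two such steps So, in these two pairs, a step measured on one core did not predict even the direction of the step on the other, but two pairs cannot show how the change would behave on any further core.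

The compounds shown leave open which difference between the two cores turns the step around. They also leave open whether a methylsulfonyl or a benzoyl group on the same nitrogen would follow either of the two steps.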